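This account rests on a few compounds, and the source may have more. Where it says the series, first, only, none or still open, it means among the compounds named here.

Measured compounds in a functional assay on BJAB cells (Homo sapiens) for antiproliferative activity, with a stated time of 4 days; on this read-out higher numbers stand for an effect only at larger amounts of compound and lower numbers for an effect already at smaller amounts:
- compound 1, `Cc1c(-c2cc(Cl)cc(Cl)c2)c(C(=O)O)nn1-c1nc(-c2cnn(C)c2)c(SC(C)C)s1`: "not active" (no number reported)
- compound 2, `COc1ccc(-c2c(C)nn(-c3nc(-c4ccc(Cl)c(Cl)c4)c(SC(C)C)s3)c2C(=O)O)cc1`: 2100 nM

Going by the values given here, compound 2 stands as the only entry with a number in this assay; for compound 1 the read-out is given without a number, so it offers no point of comparison on the scale. Among the compounds with values here, no pair of measured compounds differs in a single place, and so no measured step exists to calibrate the change now under consideration.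

Compound 3, `Cc1cc(Cl)cc(-c2c(C)nn(-c3nc(-c4ccc(Cl)c(Cl)c4)c(SC(C)C)s3)c2C(=O)O)c1`, differs from compound 2 by 3-chloro-5-methylphenyl in place of 4-methoxyphenyl on an aromatic carbon. Compound 1, which differs from compound 2 in more than one place, cannot be read as a single-change guide to this replacement. Within the data shown here, with no step to lean on, the expectation for this assay is a shift toward an effect only at somewhat larger amounts, of a size at the edge of the usual scatter rather than clearly beyond it; the step from compound 2 to compound 3 is expected as a 1.7-fold higher number from compound 2 to compound 3 (0.22 log units; within the scatter). Compound 3 is accordingly estimated at 3500 nM, with a range from 1200 nM to 12000 nM, and a real chance that only a limit and no number is returned.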

Compound 3, half-maximal effective concentration: 663 nM
The estimate for compound 3 lay 5.3-fold (0.72 log units) above the measured number; the measured number lies below the stated range.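

In this assay the aromatic carbon of the five-membered aromatic ring with 2 nitrogen, next to the ring atom that bears a carboxy group, now has its first measured step: a 3.2-fold lower number from compound 2 to compound 3 (0.50 log units; beyond the scatter) with 3-chloro-5-methylphenyl in place of 4-methoxyphenyl. The number at this position therefore depends on which substituted phenyl it carries, even though both groups have 8 heavy atoms and one six-membered aromatic ring of carbon only, and the entering group lacks the hydrogen-bond acceptor of the leaving one. Nothing measured here accounts for the step.

A single pair cannot separate the contribution of the chlorine, the methyl, the loss of the methoxy group or the changed substitution pattern, and compound 1 gives no number and differs from compound 2 in more than one place, so it adds nothing on this point. The compounds shown also leave open how a phenyl ring carrying only a 3-chloro or only a 3-methyl group, or a ring with a nitrogen such as pyridyl, would read at this position.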